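A few compounds are considered here, and "the series" means these few. Any claim that something is new, unique, unknown or untested is made for them only; others in the source may bear on it.

Working notes on the series. Among the compounds with values here, in a functional assay on Bel-7402 cells (Homo sapiens) for antiproliferative activity, read by MTT assay, with a stated time of 72 h (on this read-out higher numbers stand for weaker inhibition and lower numbers for stronger inhibition), compound 1 (`COc1ccc(Cn2c(C(=O)O)c(CNCc3cccc(OC)c3)c3ccccc32)cc1`) gives 52900 nM, the only numeric value so far. Compound 2 (`COc1cccc(CNCc2c(C(=O)O)n(Cc3ccccc3F)c3ccccc23)c1`) reads > 50000 nM, which is a limit of the assay and not a number. Within the data shown here, the single measured step, a step that the limit leaves unreadable from compound 1 to compound 2, has no readable size; it is 2-fluorophenyl in place of 4-methoxyphenyl on a saturated chain carbon bound to an aromatic nitrogen, so it sits elsewhere on the molecule and sets no size for the next change. Compound 3 (`COc1ccc(Cn2c(C(=O)O)c(CNCc3cccc(OC)c3)c3ccc(C(F)(F)F)cc32)cc1`) carries trifluoromethyl in place of hydrogen on an aromatic carbon of the shared core (trifluoromethyl in place of hydrogen on an aromatic carbon). Among the measured compounds shown here, no measured step covers this change, so the expectation in this assay is no shift beyond the scatter, anchored only on compound 1 at 52900 nM. The expected step is a 1.4-fold lower number from compound 1 to compound 3 (0.14 log units; within the scatter). For compound 3 the estimated value is 38000 nM, with an expected range of 12000 nM to 90000 nM.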

Compound 3, half-maximal inhibitory concentration: > 50000 nM
Compound 3 gave a limit, no number; the forecaster's own chance of this, stated with the estimate: 35%; middle value at least 1.3-fold (0.11 log units) from the limit.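

In this assay compound 3 gives > 50000 nM, a limit and not a number, so no new step can be read from compound 1 to compound 3: the limit of > 50000 nM in this assay, at which 2 of the 3 values shown sit. The compounds shown leave open whether trifluoromethyl in place of hydrogen on the shared core shifts the number at all, and in which direction.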